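The source may report more compounds than this note shows. Statements on the series, on what has been measured and on what is new or still open speak of the compounds shown alone.

In an assay on isolated protein for binding affinity to Oxytocin receptor (Homo sapiens) (on this read-out lower numbers stand for stronger inhibition and higher numbers for weaker inhibition), compound 1 `CC(C)C[C@@H]1C(=O)N[C@H](C2Cc3ccccc3C2)C(=O)N1[C@@H](C(=O)NC(C)C)c1ccc(-c2ccccn2)s1` gives 2.51 nM. Compound 2 `Cc1nc([C@H](C(=O)NC(C)C)N2C(=O)[C@@H](C3Cc4ccccc4C3)NC(=O)[C@H]2CC(C)C)co1` differs from it only in the group carried on the saturated chain carbon, and in this assay compound 2 gives 1.26 nM. The step of a 2.0-fold lower number from compound 1 to compound 2 (0.30 log units; within the scatter) is within the scatter, so the two measured compounds cannot be told apart on these numbers; compound 2 is simply the point from which the next change starts.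

Compound 3 `CC(C)C[C@@H]1C(=O)N[C@H](C2Cc3ccccc3C2)C(=O)N1[C@@H](C(=O)NC(C)C)c1coc(C(F)(F)F)n1` keeps everything of compound 2 except one spot: trifluoromethyl in place of methyl on an aromatic carbon. Among the measured compounds shown here, the only measured step, a 2.0-fold lower number from compound 1 to compound 2 (0.30 log units; within the scatter), swapped an entire ring system at a different position and bears only loosely on this change; no measured pair shows a methyl giving way to a trifluoromethyl. For the measured compounds named here, with no step of this kind to lean on, and the one measured step being small, the expectation for this assay is no step beyond the scatter, in either direction. Compound 3 is therefore estimated at 1.5 nM, with a range from 0.6 nM to 4 nM, which amounts to an expected step of a 1.2-fold higher number from compound 2 to compound 3 (0.08 log units; within the scatter).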

Compound 3, inhibition constant: 0.159 nM
Compound 3: middle estimate off by 9.4-fold (0.97 log units), on the high side, outside the stated range (below it).
By their numbers in this assay, from the lowest: compound 3; then compounds 2 and 1 (each within the scatter of the next).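

In this assay, trifluoromethyl in place of methyl on the five-membered aromatic ring with 1 nitrogen and 1 oxygen gives a 7.9-fold lower number from compound 2 to compound 3 (0.90 log units; beyond the scatter), so a change of one small group at this carbon moves the number beyond the scatter, something the exchange of a whole ring system between the two earlier compounds did not do. Replacing the 5-(pyridin-2-yl)thiophen-2-yl group with the trifluoromethyl-bearing ring gives a 16-fold lower number from compound 1 to compound 3 (1.20 log units; beyond the scatter), which places compound 3 clearly apart from both earlier compounds, while those two remain within the scatter of each other. The data given here offer no measured basis for explaining the size of this step.

Three compounds cannot show whether the effect follows the fluorine atoms or simply the larger group, and a difluoromethyl, a chlorine atom or a tert-butyl at the same carbon would be needed to separate those readings. Going by these compounds, it also remains open whether a trifluoromethyl gives a step of similar size on a different aromatic ring or alongside a different group on the shared core.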